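The source may report more compounds than this note shows. Statements on the series, on what has been measured and on what is new or still open speak of the compounds shown alone.

In a functional assay on QGY-7703 cells (Homo sapiens) for cytotoxicity, read by MTT assay, with a stated time of 24 h (on this read-out lower numbers stand for stronger inhibition and higher numbers for weaker inhibition), compound 1 `CN1C/C(=C\c2cccnc2)C(=O)/C(=C/c2ccccc2C(F)(F)F)C1` gives 2910 nM, compound 2 `O=C1/C(=C/c2cccnc2)CNC/C1=C\c1ccccc1C(F)(F)F` gives 3800 nM and compound 3 `O=C1/C(=C/c2cccnc2)CN(S(=O)(=O)c2ccc(F)cc2)C/C1=C\c1ccccc1C(F)(F)F` gives 6030 nM. Compound 3 stands clear of only one of the other two: the data show a 2.1-fold higher number from compound 1 to compound 3 (0.32 log units; beyond the scatter), yet also a 1.6-fold higher number from compound 2 to compound 3 (0.20 log units; within the scatter). Compound 4 `O=C1/C(=C/c2cccnc2)CN(S(=O)(=O)c2ccc(Br)cc2)C/C1=C\c1ccccc1C(F)(F)F` is compound 3 with a single change, (bromo in place of fluoro on an aromatic carbon), bromo in place of fluoro on an aromatic carbon. Within the data shown here, no measured pair alters this halogen, so the evidence is indirect. Even replacing the whole substituent on the amine nitrogen in a ring produced steps no larger than the one from methyl to (4-fluorophenyl)sulfonyl, and the remaining measured step is a 1.3-fold higher number from compound 1 to compound 2 (0.12 log units; within the scatter). On that basis, exchanging one halogen atom is expected to give no step beyond the scatter in this assay, in either direction. The estimated step is a 1.1-fold lower number from compound 3 to compound 4 (0.04 log units; within the scatter). For compound 4 the expected value is 5500 nM, with an estimated range from 2800 nM to 11000 nM.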

Compound 4, half-maximal inhibitory concentration: 5510 nM
Estimate against measurement, compound 4: 1.0-fold (0.00 log units) below; the range from low to high includes it.
By their numbers in this assay, from the lowest: compounds 1, 2, 4 and 3 (each within the scatter of the next, the first and the last beyond it).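

In this assay the halogen on the arylsulfonyl group now has a direct comparison: bromo in place of fluoro gives a 1.1-fold lower number from compound 3 to compound 4 (0.04 log units; within the scatter) and so shows that this one exchange, on an aromatic carbon para to a large group, produces no step beyond the scatter. Compound 4 also lies within the scatter of both compounds lacking a sulfonyl group, with a 1.5-fold higher number from compound 2 to compound 4 (0.16 log units; within the scatter) and a 1.9-fold higher number from compound 1 to compound 4 (0.28 log units; within the scatter) as its steps, whereas the corresponding step from compound 1 to the fluoro compound 3 was printed as beyond it. Nothing given here accounts for these values.

The compounds shown leave open how a non-halogen group at this place, such as an amine, a methoxy group or a carboxylic acid, would read out. They also leave open how an acetyl group on the amine nitrogen would compare with the sulfonyl groups.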